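Replacing the acetyl-fluorophenyl ether in compound 3

This account rests on a few compounds, and the source may have more. Where it says the series, first, only, none or still open, it means among the compounds named here.

Three compounds in the series share one core and differ only in the aryl group carried on the oxygen of the saturated carbon. Compound 1 `CN(C)c1ccc(C(=O)Nc2cccc(NC(=O)COc3ccc4c(c3)NC(=O)CC4)c2)cc1` gives 3140 nM in an assay on isolated protein for inhibition of Rho-associated protein kinase 2 (Homo sapiens), read by scintillation counting, radiometric assay and 33P incorporation, with a stated time of 40 min, in the presence of a further agent that is not named here; on this read-out lower numbers stand for stronger inhibition and higher numbers for weaker inhibition. Compound 2 `COc1cccc(OCC(=O)Nc2cccc(NC(=O)c3ccc(N(C)C)cc3)c2)c1` gives 5740 nM in the same test, and the step of a 1.8-fold higher number from compound 1 to compound 2 (0.26 log units; within the scatter) is small. Compound 3 `CC(=O)c1ccc(OCC(=O)Nc2cccc(NC(=O)c3ccc(N(C)C)cc3)c2)cc1F` gives 98 nM, the lowest number of the three: the steps of a 32-fold lower number from compound 1 to compound 3 (1.51 log units; beyond the scatter) and a 59-fold lower number from compound 2 to compound 3 (1.77 log units; beyond the scatter) are both large and clearly beyond the scatter.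

Compound 4 `CN(C)c1ccc(C(=O)Nc2cccc(NC(=O)COc3ccc4occc(=O)c4c3)c2)cc1` is not yet measured. Its change from compound 3 is a group of 11 heavy atoms (9 carbon, 2 oxygen; one six-membered aromatic ring of carbon only, one six-membered aromatic ring with 1 hetero atom) in place of a group of 10 heavy atoms (8 carbon, 1 oxygen, 1 fluorine; one six-membered aromatic ring of carbon only), on an oxygen on a saturated carbon. For the measured compounds named here, the group that enters, a fused pair of six-membered aromatic rings, is closer in kind to the fused group of compound 1 than to the single ring of compound 3. Going by the values given here, the steps that bear on this are the two that lead into compound 3; both were large, and the move away from the 4-acetyl-3-fluorophenyl group is expected to give back much of that gain. Compound 4 is therefore expected to show 1500 nM, between 400 nM and 6000 nM, a step of a 15-fold higher number from compound 3 to compound 4 (1.18 log units; beyond the scatter) toward a higher number.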

Compound 4, half-maximal inhibitory concentration: > 10000 nM
Compound 4: a limit, no number; the forecaster's own chance of this, stated with the estimate: 5%; middle value at least 6.6-fold (0.82 log units) away from the limit.
By their numbers in this assay, from the lowest: compound 3; then compounds 1 and 2 (each within the scatter of the next). At a limit, above all of these: compound 4.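

Compound 4 reads as a limit in this assay, not as a number: the limit of > 10000 nM in this assay, at which 1 of the 4 values shown sits. At this place, on an oxygen on a saturated carbon, the fused aromatic pair does not hold the gain seen with 4-acetyl-3-fluorophenyl, giving an at least 100-fold higher number from compound 3 to compound 4 (2.00 log units; beyond the scatter), and a fused group as such does not fix the reading, since the step of an at least 3.1-fold higher number from compound 1 to compound 4 (0.50 log units; beyond the scatter) separates two fused groups of equal heavy-atom count. Against the single 3-methoxyphenyl ring, the step is an at least 1.7-fold higher number from compound 2 to compound 4 (0.24 log units; that floor lies within the scatter), so no order can be read there.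

The compounds shown do not separate the acetyl from the fluorine, leaving open how 4-acetylphenyl or 3-fluorophenyl alone would read. Also open, on these data alone, are an amine in place of the acetyl and the actual number for compound 4.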